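This account rests on a few compounds, and the source may have more. Where it says the series, first, only, none or still open, it means among the compounds named here.

Compound 1, `CCc1nnsc1CO/N=C/c1c(C)nn(C)c1Oc1ccccc1Cl`: in a functional assay on Huh-7 cells (Homo sapiens) for inhibition, read by MTT assay, with a stated time of 48 h (a lower number here means a stronger inhibitor, a higher number a weaker inhibitor), compound 1 gives > 50000 nM, which is a limit of the assay and not a number.
Compound 2, `CCc1nnsc1CO/N=C/c1c(C)nn(C)c1Oc1ccc(C)cc1`: in this assay compound 2 gives > 50000 nM, again a limit rather than a number.
Compound 3, `Cc1nnsc1CO/N=C/c1c(C)nn(C)c1Cl`: in this assay compound 3 gives > 50000 nM, once more a limit.

Compound 3 therefore stands at the edge of what this assay reports, and it shares that position with the other two compounds: all three sit at the limit of > 50000 nM in this assay, at which 3 of the 3 values shown sit. Among the compounds with values here, the one step among measured compounds that differ in a single place, a step that the two limits leave unreadable from compound 1 to compound 2, runs from one limit to another, so its size cannot be read, and it concerns the group on the oxygen rather than the part of the molecule at issue here.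

Compound 4, `CCc1nnsc1CO/N=C/c1c(C)nn(C)c1Cl`, differs from compound 3 by methyl in place of hydrogen on a saturated chain carbon bound to an aromatic carbon. Within the data shown here, no measured step bears on this change; the values of compound 1 and compound 2, which carry the ethyl already, show only that they too remain at the limit. With nothing to suggest a readable step in either direction, compound 4 is expected to stay at the limit as well. In this assay compound 4 is estimated at 100000 nM, with a range from 30000 nM to 500000 nM. The step that this estimate implies, a step that the limit leaves unreadable from compound 3 to compound 4, is expected to be no larger than the scatter.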

Compound 4, half-maximal inhibitory concentration: > 50000 nM
Compound 4: only a limit was reported; the forecaster's own chance of this, stated with the estimate: 90%; the middle value is on the limit's open side.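

No step can be read from compound 1, compound 2 or compound 3 to compound 4, since in this assay each of these values is a limit and not a number: the limit of > 50000 nM in this assay, at which 4 of the 4 values shown sit.

The compounds shown leave open whether methyl in place of hydrogen on a saturated chain carbon bound to an aromatic carbon, or any other change among them, alters inhibition in this assay.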